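Sulfonyl-side replacement in a factor X sulfonamide series

This account rests on a few compounds, and the source may have more. Where it says the series, first, only, none or still open, it means among the compounds named here.

Measured so far:
compound 1 `O=C1[C@@H](NS(=O)(=O)c2nc3cc(Cl)ccc3[nH]2)CCN1Cc1cc2c[nH]ccc-2n1` — 31%
compound 2 `O=C1[C@@H](NS(=O)(=O)c2nc3cc(Cl)ccc3[nH]2)CCN1Cc1cc2[nH]cccc-2n1` — 14%

In an assay on isolated protein for inhibition of coagulation factor X (Oryctolagus cuniculus), tested at 1 uM (a lower number here means less inhibition, a higher number more inhibition at the concentration tested (going by the name of the read-out)), compound 1 gives 31%, the higher of the two numbers; compound 2 gives 14%. Among the measured compounds shown here, the one step known is a number 17 percentage points lower from compound 1 to compound 2 (beyond the scatter), a swap on the saturated chain carbon bound to the amide-type nitrogen.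

Compound 3 `O=C1[C@@H](NS(=O)(=O)c2cc3ccnc(Cl)c3s2)CCN1Cc1cc2c[nH]ccc-2n1` differs from compound 1 elsewhere, on the sulfonyl sulfur: a group of 10 heavy atoms (7 carbon, 1 nitrogen, 1 sulfur, 1 chlorine; one five-membered aromatic ring with 1 hetero atom, one six-membered aromatic ring with 1 hetero atom) in place of a group of 10 heavy atoms (7 carbon, 2 nitrogen, 1 chlorine; one five-membered aromatic ring with 2 hetero atoms, one six-membered aromatic ring of carbon only), on a sulfonyl sulfur. For the measured compounds named here, no measured step touches this side of the shared core, so the known step gives no guide, and an expectation of no change beyond the scatter is the default, with wide uncertainty. For compound 3 the expected step is a number 1 percentage points lower from compound 1 to compound 3 (within the scatter). Compound 3 is estimated at 30%, with a range from 8% to 58%.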

Compound 3, a percentage reported as inhibition, at one concentration (the size of the read-out at that concentration, not a potency): 25%
Estimate against measurement, compound 3: 5 percentage points above, within the range that was stated.
By their numbers in this assay, from the lowest: compound 2; then compounds 3 and 1 (each within the scatter of the next).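

In this assay, the sulfonyl sulfur accepts the exchange of 5-chloro-1H-benzimidazol-2-yl for a group with two rings of different hetero atoms, with a number 6 percentage points lower from compound 1 to compound 3 (within the scatter). In this one pair, a group with 1 hydrogen-bond donor gives way to one with 0 hydrogen-bond donors and 2 hydrogen-bond acceptors, without a step beyond the scatter. No supporting data bear on why this exchange reads as it does.

Still open, going by these compounds, is whether the same exchange reads alike with the group of compound 2 on the other side. Also open, on these data alone, is how a methoxy group in place of the chlorine would read at the sulfonyl side.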